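From Amino Link Back to Oxy Link on the Shared Core

The source may report more compounds than this note shows. Statements on the series, on what has been measured and on what is new or still open speak of the compounds shown alone.

In an ADME assay on L6 cells (Rattus norvegicus) for cytotoxicity, read by resazurin assay, with a stated time of 72 h (a higher number here means a weaker inhibitor, a lower number a stronger inhibitor), compound 1 `CCN(CC)CC(=O)OC1CC2(N(C)C)CC(c3ccccc3)C1C(c1ccccc1)C2` gives 30100 nM, compound 2 `O=C(CN1CCCCC1)OC1CC2(N3CCCC3)CC(c3ccccc3)C1C(c1ccccc1)C2` gives 14200 nM and compound 3 `CN1CCN(CC(=O)NC2CC3(N(C)C)CC(c4ccccc4)C2C(c2ccccc2)C3)CC1` gives 66200 nM. Compound 3 thus has the highest number of the three, lying nearest to compound 1 and furthest from compound 2.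

Compound 4 `CN(C)C12CC(OC(=O)CN3CCCCC3)C(C(c3ccccc3)C1)C(c1ccccc1)C2` keeps the dimethylamino group of compound 3 but carries (((piperidin-1-yl)methyl)carbonyl)oxy in place of (((4-methylpiperazin-1-yl)methyl)carbonyl)amino on a saturated ring carbon.

Going by the values given here, only one measured step bears directly on this change. It is a 2.2-fold higher number from compound 1 to compound 3 (0.34 log units; beyond the scatter), a modest rise beyond the scatter that accompanies the move from an oxy-linked to an amino-linked side chain. The change to compound 4 runs the opposite way, so a fall of similar size is the natural expectation. Compound 2 supports this, since it has the same (((piperidin-1-yl)methyl)carbonyl)oxy group and gives 14200 nM, although it lacks the dimethylamino group. The expected step is modest and towards a lower number, a 3.0-fold lower number from compound 3 to compound 4 (0.48 log units; beyond the scatter). For compound 4 the estimated value is 22000 nM, with an expected range from 11000 nM to 45000 nM.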

Compound 4, half-maximal inhibitory concentration: 29300 nM
Compound 4: middle estimate off by 1.3-fold (0.12 log units), on the low side; the measured number falls inside the stated range.
By their numbers in this assay, from the lowest: compound 2; then compounds 4 and 1 (each within the scatter of the next); then compound 3.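

In this assay, going back to an oxy link with a piperidin-1-yl end gives a 2.3-fold lower number from compound 3 to compound 4 (0.35 log units; beyond the scatter) and so reverses the direction of a 2.2-fold higher number from compound 1 to compound 3 (0.34 log units; beyond the scatter) on the same dimethylamino-bearing core, leaving amino-linked compound 3 with a higher number than either oxy-linked dimethylamino compound. At the chain end, compound 4 shows a 1.0-fold lower number from compound 1 to compound 4 (0.01 log units; within the scatter) for piperidin-1-yl in place of diethylamino on a saturated chain carbon bound to a carbonyl carbon, so this swap does not register in the readout. The other ring substituent does register, with a 2.1-fold higher number from compound 2 to compound 4 (0.31 log units; beyond the scatter) for dimethylamino in place of pyrrolidin-1-yl on a saturated ring carbon, a difference that is modest but beyond the scatter.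

Because the step from compound 3 to compound 4 changes both the link and the ring at once, the compounds shown leave open how much belongs to each, which a 4-methylpiperazin-1-yl group on an oxy link or a piperidin-1-yl group on an amino link would separate, and how a morpholin-4-yl group would read at the chain end. No measurement at hand explains any of these steps.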